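Replacing a primary amide with a pyrrolidine amide

The source may report more compounds than this note shows. Statements on the series, on what has been measured and on what is new or still open speak of the compounds shown alone.

Compound 1, `COc1ccc(OC/C(F)=C\CN)cc1`: 310 nM
Compound 2, `NC/C=C(/F)COc1ccc(C(F)(F)F)cc1`: 130 nM
Compound 3, `NC/C=C(/F)COc1ccc(C(N)=O)cc1`: > 30000 nM

In an assay on isolated protein for inhibition of Amine oxidase [flavin-containing] B (Homo sapiens), read by Amplex Red (on this read-out higher numbers stand for weaker inhibition and lower numbers for stronger inhibition), compound 1 gives 310 nM and compound 2 gives 130 nM, a change of a 2.4-fold lower number from compound 1 to compound 2 (0.38 log units; beyond the scatter). Compound 3 gives only a limit of the assay, > 30000 nM. This is the limit of > 30000 nM in this assay, at which 1 of the 3 values shown sits, so the true number for compound 3 is not known. The steps of an at least 96-fold higher number from compound 1 to compound 3 (1.98 log units; beyond the scatter) and an at least 230-fold higher number from compound 2 to compound 3 (2.36 log units; beyond the scatter) are both large. Compound 4, `NC/C=C(/F)COc1ccc(C(=O)N2CCCC2)cc1`, differs from compound 3 by pyrrolidin-1-yl in place of amino on a carbonyl carbon. Going by the values given here, no measured step touches the amide nitrogen, so this change is untested here, and the two large steps leading to compound 3 give no hint of recovery. Compound 4 is therefore expected to remain weak, with an at least 1.2-fold lower number from compound 3 to compound 4 (0.07 log units; that floor lies within the scatter) estimated as no step beyond the scatter. The estimate for compound 4 is 25000 nM, expected between 4000 nM and 150000 nM.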

Compound 4, half-maximal inhibitory concentration: 11000 nM
The estimate for compound 4 lay 2.3-fold (0.36 log units) above the measured number; the range from low to high includes it.
By their numbers in this assay, from the lowest: compound 2; then compound 1; then compound 4. At a limit, above all of these: compound 3.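

Pyrrolidin-1-yl in place of amino on the carbonyl carbon gives an at least 2.7-fold lower number from compound 3 to compound 4 (0.43 log units; beyond the scatter), so on this carbonyl a measurable number returns once the amino group is replaced. The true size of this step stays unknown because compound 3 stands only at a limit of the assay: the limit of > 30000 nM in this assay, at which 1 of the 4 values shown sits.

The compounds shown leave open whether the ring itself matters or whether any replacement of the amino group would do the same. Dimethylamino or piperidin-1-yl on the same carbonyl carbon would help separate these two readings.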